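Benzoxazole Thioether in Place of the Phenyl-oxadiazole

The compounds below may be only part of what the source reports. "The series", "measured", "known", "first", "only" and "open" are said of these compounds alone.

Of the compounds shown here, three on a shared core have been tested in a functional assay on Jurkat cells (Homo sapiens) for inhibition; on this read-out higher numbers stand for weaker inhibition and lower numbers for stronger inhibition. Compound 3, `CC(C)[C@H](NC(=O)COc1cccc2ccccc12)C(=O)N[C@@H](CC(=O)O)C(=O)CSc1nc(-c2ccccc2)no1`, gives 102000 nM in this assay and stands highest of the two numbers shown; its nearest neighbour is compound 1, `CC(C)[C@H](NC(=O)COc1cccc2ccccc12)C(=O)N[C@@H](CC(=O)O)C(=O)COc1cc(C(F)(F)F)n(C)n1`, which gives 46000 nM. Compound 2, `CCOC(=O)c1c(C)noc1OCC(=O)[C@H](CC(=O)O)NC(=O)[C@@H](NC(=O)COc1cccc2ccccc12)C(C)C`, reaches only a limit of this assay, recorded as > 200000 nM.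

Compound 4, `CC(C)[C@H](NC(=O)COc1cccc2ccccc12)C(=O)N[C@@H](CC(=O)O)C(=O)CSc1nc2ccccc2o1`, has not yet been measured. It differs from compound 3 in a single place: 1,3-benzoxazol-2-yl in place of 3-phenyl-1,2,4-oxadiazol-5-yl on a sulfur.

The measured steps all concern exchanges of the heteroaryl group attached through oxygen or sulfur at that same chain carbon. They read a 2.2-fold higher number from compound 1 to compound 3 (0.35 log units; beyond the scatter), an at least 4.3-fold higher number from compound 1 to compound 2 (0.63 log units; beyond the scatter) and an at least 1.9-fold lower number from compound 2 to compound 3 (0.29 log units; that floor lies within the scatter). Each exchange shifted the number only modestly, in either direction, and one of them is bounded by a limit rather than a number.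

Since the change to compound 4 is again an exchange of the heteroaryl on the sulfur, a step of similar modest size is expected, with no strong reason for a particular direction; the estimate is a 1.3-fold lower number from compound 3 to compound 4 (0.11 log units; within the scatter). Compound 4 is therefore expected to give about 80000 nM in this assay, with a range from 30000 nM to 200000 nM.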

Compound 4, half-maximal inhibitory concentration: > 200000 nM
Compound 4: only a limit was reported; the forecaster's own chance of this, stated with the estimate: 20%; middle value at least 2.5-fold (0.39 log units) from the limit.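

Compound 4 gives only a limit in this assay, so the exchange of 3-phenyl-1,2,4-oxadiazol-5-yl for 1,3-benzoxazol-2-yl on a sulfur is known only by its floor, an at least 1.9-fold higher number from compound 3 to compound 4 (0.29 log units; that floor lies within the scatter), and that floor lies within the scatter. The comparison with the oxygen-linked pyrazole is clearer, an at least 4.3-fold higher number from compound 1 to compound 4 (0.63 log units; beyond the scatter), which is beyond the scatter and leaves compound 1 with the lowest number of the four, so a second fused or phenyl-bearing sulfur-linked group has brought no gain over it. The step between compound 2 and compound 4 cannot be read, and the assay limit now restricts what this position can show: the limit of > 200000 nM in this assay, at which 2 of the 4 values shown sit.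

From the compounds shown here alone, how far compound 4 truly lies from compound 3 remains open, as does whether the 1,3-benzoxazol-2-yl group would fare differently attached through oxygen rather than sulfur. Going by these compounds, it is also open whether an amine or a carboxylic acid on that group would bring the number back under the limit.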